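Swapping 3-methoxyphenyl for 2-methoxyphenyl on an amide-type nitrogen

This account rests on a few compounds, and the source may have more. Where it says the series, first, only, none or still open, it means among the compounds named here.

Measured in a functional assay on A549 cells (Homo sapiens) for inhibition, read by MTT assay, with a stated time of 72 h; a lower number here means a stronger inhibitor, a higher number a weaker inhibitor:
- Compound 1 `CCc1ccc(NC(=O)C2CCN(C/C=C/c3ccccc3)CC2)cc1`: 19600 nM
- Compound 2 `CCCc1ccc(NC(=O)C2CCN(C/C=C/c3ccccc3)CC2)cc1`: 9470 nM
- Compound 3 `COc1cccc(NC(=O)C2CCN(C/C=C/c3ccccc3)CC2)c1`: 50500 nM

Compound 3 has the highest number of the three, making it the weakest inhibitor measured so far. Compound 4 `COc1ccccc1NC(=O)C1CCN(C/C=C/c2ccccc2)CC1` awaits measurement. It carries 2-methoxyphenyl in place of 3-methoxyphenyl on an amide-type nitrogen. Two measured steps changed the group on that nitrogen: a 2.6-fold higher number from compound 1 to compound 3 (0.41 log units; beyond the scatter) and a 5.3-fold higher number from compound 2 to compound 3 (0.73 log units; beyond the scatter). Both were modest, and neither moved a methoxy group, so they suggest a size but no firm direction. Compound 3 sits at the top of this small set with 50500 nM, which tilts the expectation slightly downward. In this assay the expected change is small: a 1.7-fold lower number from compound 3 to compound 4 (0.23 log units; within the scatter). For compound 4 the estimated value is 30000 nM, with an expected range from 10000 nM to 80000 nM.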

Compound 4, half-maximal inhibitory concentration: > 100000 nM
Compound 4 gave a limit, no number; the forecaster's own chance of this, stated with the estimate: 10%; middle value at least 3.3-fold (0.52 log units) from the limit.
By their numbers in this assay, from the lowest: compound 2; then compound 1; then compound 3. At a limit, above all of these: compound 4.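

Compound 4 gave no number, only a limit of the assay: the limit of > 100000 nM in this assay, at which 1 of the 4 values shown sits. Placing the methoxy group as 2-methoxyphenyl instead of 3-methoxyphenyl gives an at least 1.9-fold higher number from compound 3 to compound 4 (0.29 log units; that floor lies within the scatter), so this step alone does not clearly separate the two compounds. Against the other two groups on the amide-type nitrogen the gap is clearer, with an at least 5.1-fold higher number from compound 1 to compound 4 (0.70 log units; beyond the scatter) and an at least 10-fold higher number from compound 2 to compound 4 (1.02 log units; beyond the scatter), and the second of these is the largest step seen so far.

On these data alone, the true size of the change from 3-methoxyphenyl to 2-methoxyphenyl stays unknown. As far as these compounds go, it also remains open whether an amine or a carboxylic acid on this ring would give a lower number than compound 2 does.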